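Methoxy for hydroxy on the pendant phenol of compound 2

This account rests on a few compounds, and the source may have more. Where it says the series, first, only, none or still open, it means among the compounds named here.

Three members of the series have numbers in a functional assay on MDA-MB-435 cells (Homo sapiens) for inhibition, read by sulforhodamine B assay, with a stated time of 48 h, tested at 0.1 uM; on this read-out higher numbers stand for a weaker effect at the one concentration tested and lower numbers for a stronger effect. Compound 1 `O=C(Nc1cccc(-n2cc(-c3ccncc3)c(-c3cc(O)cc(Cl)c3)n2)c1)Nc1ccc(Cl)c(C(F)(F)F)c1` gives 94%, compound 2 `O=C(Nc1cccc(-n2cc(-c3ccncc3)c(-c3cc(O)cc(Cl)c3)n2)c1)Nc1ccc(Cl)c(Cl)c1` gives 93%, and compound 3 `COc1cc(Cl)cc(-c2nn(-c3cccc(NC(=O)Nc4cc(C(F)(F)F)cc(C(F)(F)F)c4)c3)cc2-c2ccncc2)c1` gives 98%. The gaps between these three all fall inside the usual scatter, so compound 2 sits level with the others. Among the measured compounds shown here, the single one-place step in the set, a number 1 percentage points lower from compound 1 to compound 2 (within the scatter), concerns the urea-borne aryl group and shows no resolvable effect.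

Compound 4 `COc1cc(Cl)cc(-c2nn(-c3cccc(NC(=O)Nc4ccc(Cl)c(Cl)c4)c3)cc2-c2ccncc2)c1` differs from compound 2 by methyl in place of hydrogen on an oxygen on an aromatic ring. For the measured compounds named here, no measured step isolates this change. Compound 3 already carries the 3-chloro-5-methoxyphenyl group, but it also carries a different urea aryl, so only the two numbers can be compared: compound 3 at 98% against compound 2 at 93%, a gap within the scatter. For compound 4 the step of a number 2 percentage points higher from compound 2 to compound 4 (within the scatter) is therefore expected to remain within the scatter. Compound 4 is estimated at 95%, with a range from 88% to 101%.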

Compound 4, a percentage reported as activity, at one concentration (the size of the read-out at that concentration, not a potency): 99%
Compound 4: middle estimate off by 4 percentage points, on the low side; the measured number falls inside the stated range.
By their numbers in this assay, from the lowest: compounds 2, 1, 3 and 4 (each within the scatter of the next).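

Among the compounds shown here, the step of a number 6 percentage points higher from compound 2 to compound 4 (within the scatter) is the first one-place reading of methyl in place of hydrogen on the oxygen on the aromatic ring, which the earlier compounds could only suggest through a comparison that also changed the urea aryl. In this assay, hydroxy and methoxy therefore read level in the 3-chloro-5-substituted phenyl group when the 3,4-dichlorophenyl urea is held constant, so this change has no resolvable effect at the one concentration tested. Nothing available accounts for this reading.

Going by these compounds, whether an amine or a longer alkoxy chain at this position would separate from compound 2 remains open. Also open, on these data alone, is whether compound 2 and compound 4 would stay level in a full concentration-response measurement.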